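Amide aryl change from compound 2 to compound 4

The source may report more compounds than this note shows. Statements on the series, on what has been measured and on what is new or still open speak of the compounds shown alone.

Compound 2 `CS(=O)(=O)N1c2ccccc2CCC1C(=O)Nc1cccc(Cl)c1` gives 1000 nM in a functional assay on HEK293 cells for positive allosteric modulation of metabotropic glutamate receptor 5 (Rattus norvegicus), read by fluorescence and calcium flux (a higher number here means that more compound is needed for the effect, a lower number that less compound is needed), the lowest of the two numbers on hand. Compound 1 `CCC(C(=O)Nc1cccc(Cl)c1)N(c1ccccc1Cl)S(C)(=O)=O` gives 3300 nM in this assay, a higher number than compound 2 beyond the scatter. Compound 3 `Cn1cnc(S(=O)(=O)N2c3ccccc3CCC2C(=O)Nc2cccc(Cl)c2)c1` reports only a limit, > 10000 nM, in this assay. Among the compounds with values here, the one measured step, an at least 10-fold higher number from compound 2 to compound 3 (1.00 log units; beyond the scatter), lies at the sulfonyl sulfur. It runs into the assay ceiling (the limit of > 10000 nM in this assay, at which 1 of the 3 values shown sits), so its full size is not known.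

Compound 4 `CS(=O)(=O)N1c2ccccc2CCC1C(=O)Nc1ccccn1` differs from compound 2 at the amide nitrogen: pyridin-2-yl in place of 3-chlorophenyl on an amide-type nitrogen. Within the data shown here, no measured step touches the amide aryl; the step from compound 2 to compound 3 concerns a different part of the molecule and does not bear on this change. Among the measured compounds shown here, with no comparable step available, the working expectation for compound 4 is a moderate rise in the number, a 3.0-fold higher number from compound 2 to compound 4 (0.48 log units; beyond the scatter), carrying a wide uncertainty. Compound 4 is estimated at 3000 nM in this assay, between 800 nM and 12000 nM.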

Compound 4, half-maximal effective concentration: 1300 nM
Compound 4: middle estimate off by 2.3-fold (0.36 log units), on the high side, and the stated range covers the measured number.
By their numbers in this assay, from the lowest: compounds 2 and 4 (each within the scatter of the next); then compound 1. At a limit, above all of these: compound 3.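

In this assay, the amide aryl position gives its first reading, and the exchange leaves the number within the scatter: a 1.3-fold higher number from compound 2 to compound 4 (0.11 log units; within the scatter). In this pair, the chlorine of 3-chlorophenyl is not needed to keep the number, and a pyridin-2-yl ring with its ring nitrogen is tolerated on the amide-type nitrogen. Nothing measured here gives a reason for this outcome.

Still open, from the compounds shown here alone, is whether this tolerance extends to other groups on the amide-type nitrogen, such as pyridin-3-yl, unsubstituted phenyl or a saturated ring like cyclohexyl. Also open, going by these compounds, is whether any such group, combined with a sulfonyl substituent such as ethyl or cyclopropyl, would bring the number below that of compound 2, 1000 nM.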